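The source may report more compounds than this note shows. Statements on the series, on what has been measured and on what is new or still open speak of the compounds shown alone.

Working notes on the series. Of the compounds shown here, three have been read so far in a functional assay, read by spectrophotometry, with a stated time of 30 min; a lower number here means a stronger inhibitor, a higher number a weaker inhibitor. Compound 1 `CC(C)(C)c1cc(CCC(=O)NCC2CCN(Cc3ccccc3)CC2)cc(C(C)(C)C)c1O` gives 63400 nM there, compound 2 `CC(C)(C)c1cc(/C=C/C(=O)NC2CCN(Cc3ccccc3)CC2)cc(C(C)(C)C)c1O` gives 71900 nM and compound 3 `COc1ccc(CN2CCC(CCNC(=O)/C=C/c3cc(C(C)(C)C)c(O)c(C(C)(C)C)c3)CC2)cc1` gives 61200 nM on the same read-out. Compound 3 stands level with the other two: all three values lie within the scatter of one another, so these numbers set no order among them. For the measured compounds named here, the three compounds differ from one another in more than one place, and no measured pair isolates a single change.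

Compound 4 `CC(C)(C)c1cc(/C=C/C(=O)NCCC2CCN(Cc3ccccc3Cl)CC2)cc(C(C)(C)C)c1O` differs from compound 3 by one change, 2-chlorophenyl in place of 4-methoxyphenyl on a saturated chain carbon bound to an amine nitrogen in a ring. Read one bond further out, this is 4-methoxybenzyl to 2-chlorobenzyl. Going by the values given here, no measured step shows what this change does in this assay. The expectation rests only on how close the values are so far, with compound 2 at 71900 nM and compound 3 at 61200 nM despite their differences. The estimated step is small, expected to stay within the scatter with a slight lean toward a lower number: a 1.2-fold lower number from compound 3 to compound 4 (0.09 log units; within the scatter). For compound 4 the expected value is 50000 nM, with an estimated range of 18000 nM to 110000 nM.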

Compound 4, half-maximal inhibitory concentration: 80200 nM
Compound 4: the middle estimate sits 1.6-fold (0.21 log units) below what was measured, and the stated range covers the measured number.
By their numbers in this assay, from the lowest: compounds 3, 1, 2 and 4 (each within the scatter of the next).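

For the compounds shown here, compound 3 and compound 4 form the first pair that differs in one place, and in this assay the step reads a 1.3-fold higher number from compound 3 to compound 4 (0.12 log units; within the scatter). At this place, on a saturated chain carbon bound to an amine nitrogen in a ring, 2-chlorophenyl and 4-methoxyphenyl therefore stand level, even though the change takes away the one hydrogen-bond acceptor of the leaving group and replaces its oxygen-bearing substituent with chlorine. No supporting data bear on why the two groups read alike.

This single step changes the identity and the ring position of the substituent together, so it cannot show what either contributes alone, and one pair says nothing about how far this place would accept groups of a different kind. On these data alone, whether a carboxylic acid or a primary amine on this phenyl ring, or a pyridine ring in its place, would give a step beyond the scatter remains open, as does whether any such step would carry over to the shared core with its other linkers.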